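The source may report more compounds than this note shows. Statements on the series, on what has been measured and on what is new or still open speak of the compounds shown alone.

Working notes on the series. Compound 1 `CC1=C(C(=O)Nc2ccc(F)cc2)C(c2ccc([N+](=O)[O-])cc2)N=C(SCc2ccccc2Cl)N1` and compound 2 `CC1=C(C(=O)Nc2ccc(F)cc2)C(c2ccc([N+](=O)[O-])cc2)N=C(SCc2cccc(Cl)c2)N1` share one core and differ only in the chlorobenzylsulfanyl arm; compound 3 `COc1ccc(C2N=C(SCc3ccccc3Cl)NC(C)=C2C(=O)Nc2ccc(Br)cc2)cc1` sits on a second core and carries the arm of compound 1; compound 4 `COc1ccc(C2N=C(SCc3cccc(Cl)c3)NC(C)=C2C(=O)Nc2ccc(Br)cc2)cc1` is the unmeasured partner of compound 3 on that second core.

In a functional assay on the whole organism (artery, strain albino) with Rattus norvegicus as the target, with a stated time of 600 min, at a dose of 10 mg/kg by the oral route (on this read-out higher numbers stand for more inhibition at the one dose given (going by the name of the read-out) and lower numbers for less inhibition), compound 1 gives 17.4%. In this assay compound 2 gives 16.4%, so the change 3-chlorophenyl in place of 2-chlorophenyl on a saturated chain carbon bound to a sulfur amounts to a number 1 percentage points lower from compound 1 to compound 2 (within the scatter). In this assay compound 3 gives 13.3%. The difference between the core of compound 3 and the core of compound 1 is not broken down here; the two values lie within the scatter of each other and nothing further is read from them.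

Compound 4 differs from compound 3 by 3-chlorophenyl in place of 2-chlorophenyl on a saturated chain carbon bound to a sulfur. The place is the same word for word as between compound 1 and compound 2, so this is the same change carried onto the second core. The change has been measured only once. On the second core the expected step is a number 0.8 percentage points lower from compound 3 to compound 4 (within the scatter), to be set beside a number 1 percentage points lower from compound 1 to compound 2 (within the scatter), and it is expected to stay small because a number 1 percentage points lower from compound 1 to compound 2 (within the scatter) was within the scatter. Compound 4 is therefore expected to give 12.5% in this assay, with a range from 4% to 22%.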

Compound 4, a percentage reported as inhibition, in the whole organism at one dose (the size of the read-out at that dose, not a potency): 32.8%
Compound 4: the middle estimate sits 20.3 percentage points below what was measured; the measured number lies above the stated range.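

In this assay, the change from 2-chlorophenyl to 3-chlorophenyl on a saturated chain carbon bound to a sulfur does not carry over from one core to the other with the same size: the same change on two cores in this assay, a number 1 percentage points lower (within the scatter) from compound 1 to compound 2 and a number 19.5 percentage points higher (beyond the scatter) from compound 3 to compound 4, 20.5 percentage points apart, beyond the scatter of two such steps

On the second core the step is a number 19.5 percentage points higher from compound 3 to compound 4 (beyond the scatter), so the 3-chlorophenyl arm gives the higher number there, while on the first core the step is a number 1 percentage points lower from compound 1 to compound 2 (within the scatter) and no order between the two arms can be read. This rests on one pair per core at a single dose, and the two cores differ in more than one place, with nitrophenyl and fluorophenyl on the first and methoxyphenyl and bromophenyl on the second, so the result does not show which of these groups goes with the larger step, nor how the change would behave on a third core.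

Still open, from the compounds shown here alone, is whether swapping only the nitrophenyl for the methoxyphenyl, or only the fluorophenyl for the bromophenyl, is enough to bring out the larger step. Also open, going by these compounds, is how the arm responds when the chlorine gives way to a carboxylic acid or an amine, or when a longer chain replaces the single carbon bound to the sulfur.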